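This account rests on a few compounds, and the source may have more. Where it says the series, first, only, none or still open, it means among the compounds named here.

Compound 1 `CNc1nc(SCc2nc3ccccc3[nH]2)nc(-c2ccccc2)c1C#N` gives 3.2 nM
Compound 2 `CCNc1nc(SCc2nc3ccccc3[nH]2)nc(-c2ccccc2)c1C#N` gives 2.87 nM
Compound 3 `N#Cc1c(NNC(N)=S)nc(SCc2nc3ccccc3[nH]2)nc1-c1ccccc1` gives 3.37 nM

In a functional assay on NCI-H460 cells (Homo sapiens) for cytotoxicity, read by MTT assay, with a stated time of 3 days (on this read-out lower numbers stand for stronger inhibition and higher numbers for weaker inhibition), compound 3 gives 3.37 nM and sits level with the other two compounds: a 1.1-fold higher number from compound 1 to compound 3 (0.02 log units; within the scatter) and a 1.2-fold higher number from compound 2 to compound 3 (0.07 log units; within the scatter) are both within the scatter. Compound 4 `N#Cc1c(-c2ccccc2)nc(SCc2nc3ccccc3[nH]2)nc1N1CCNCC1` carries piperazin-1-yl on the aromatic carbon ortho to a cyano group, and a group of 6 heavy atoms (4 carbon, 2 nitrogen; one six-membered non-aromatic ring with 2 hetero atoms) in place of a group of 5 heavy atoms (1 carbon, 3 nitrogen, 1 sulfur; no ring), on an aromatic carbon is the whole change. The measured steps all concern groups with no ring at this place, and a 1.1-fold lower number from compound 1 to compound 2 (0.05 log units; within the scatter) also stays within the scatter. They therefore offer only indirect guidance for adding a ring, but they show no sensitivity here. The expected change is a 1.0-fold higher number from compound 3 to compound 4 (0.00 log units; within the scatter) in this assay and no shift beyond the scatter in either direction is expected. Compound 4 is estimated at 3.4 nM (expected range 1.3 nM to 9 nM).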

Compound 4, half-maximal inhibitory concentration: 7.35 nM
The estimate for compound 4 lay 2.2-fold (0.33 log units) below the measured number; measured number inside the range.
By their numbers in this assay, from the lowest: compounds 2, 1 and 3 (each within the scatter of the next); then compound 4.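

Modest steps beyond the scatter appear here for the first time, namely a 2.2-fold higher number from compound 3 to compound 4 (0.34 log units; beyond the scatter) and a 2.6-fold higher number from compound 2 to compound 4 (0.41 log units; beyond the scatter) and also a 2.3-fold higher number from compound 1 to compound 4 (0.36 log units; beyond the scatter) in this assay when piperazin-1-yl enters on this aromatic carbon. The position, level across the three groups without a ring, therefore does respond to this change, though only mildly. Nothing available accounts for the shift.

Going by these compounds alone, compound 4 is the only ring example, so it stays open whether morpholin-4-yl or piperidin-1-yl would behave alike. As far as these compounds go, whether a longer chain such as propylamino would stay level with compound 2 is equally open.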